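The compounds below may be only part of what the source reports. "The series", "measured", "known", "first", "only" and "open" are said of these compounds alone.

Measured compounds:
- compound 1 `Cn1c(Cc2nn(C)c(=O)c3ccccc23)nnc1SCCCCCCCC(=O)Nc1ccc(Cl)cc1Cl` gives 2200 nM in an assay on 32D cells for inhibition of interleukin-15 (Mus musculus), read by resazurin assay, with stated times of 30 min and 2.5 days, in the presence of a further agent that is not named here; on this read-out lower numbers stand for stronger inhibition and higher numbers for weaker inhibition
- compound 2 `CCOC(CCn1c(Cc2nn(C)c(=O)c3ccccc23)nnc1SCCCCCCCC(=O)Nc1ccc(Cl)cc1Cl)OCC` gives 12100 nM in this assay

For the measured compounds named here, compound 1 holds the lower of the two numbers in this assay; the only step from it so far, a 5.5-fold higher number from compound 1 to compound 2 (0.74 log units; beyond the scatter), is a weakening. Compound 3 `Cn1c(Cc2nn(CCCO)c(=O)c3ccccc23)nnc1SCCCCCCCC(=O)Nc1ccc(Cl)cc1Cl` is not yet measured. It differs from compound 1 by 2-hydroxyethyl in place of hydrogen on a saturated chain carbon bound to an aromatic nitrogen. Going by the values given here, the single step that bears on this change is a 5.5-fold higher number from compound 1 to compound 2 (0.74 log units; beyond the scatter), in which a larger group entered at the same place; the hydroxyethyl group of compound 3 is smaller and carries one hydrogen-bond donor and one acceptor, so the same direction with a smaller size is the expectation. The expected step is a 2.0-fold higher number from compound 1 to compound 3 (0.31 log units; beyond the scatter), a weakening that may lie only a little beyond the scatter. Compound 3 is estimated at 4500 nM in this assay, with a range of 1800 nM to 12000 nM.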

Compound 3, half-maximal inhibitory concentration: > 30000 nM
Compound 3: no number, only a limit (the forecaster's own chance of this, stated with the estimate: 5%); at least 6.6-fold (0.82 log units) between middle value and limit.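

Both steps from compound 1 at a saturated chain carbon bound to an aromatic nitrogen go the same way in this assay, and the smaller group does not give the smaller step: an at least 13-fold higher number from compound 1 to compound 3 (1.13 log units; beyond the scatter) with 2-hydroxyethyl, against a 5.5-fold higher number from compound 1 to compound 2 (0.74 log units; beyond the scatter) with 2,2-diethoxyethyl. The first is rated large and the second modest, so the size of the entering group alone does not order these two changes. The step to compound 3 is a bound and not a measured size: the limit of > 30000 nM in this assay, at which 1 of the 3 values shown sits.

The compounds shown cannot separate the effect of the chain from that of its hydroxyl, since a plain propyl chain does not appear among them. From the compounds shown here alone, how a terminal amine or carboxylic acid on the same chain would read also remains open.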